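The source may hold more compounds than are shown below. What is called first, only, known or untested is meant among the compounds shown, and "the series" means these compounds.

Measured compounds:
Compound 1, `CCN(CC)S(=O)(=O)c1ccc(S(=O)(=O)N2CCC[C@@H](C(=O)NC3CN(C(=O)C4CC4)C3)C2)cc1`, gives 18500 nM in a functional assay on BXPC-3 cells (Homo sapiens) for inhibition, read by MTT assay, with a stated time of 7 days; on this read-out lower numbers stand for stronger inhibition and higher numbers for weaker inhibition.
Compound 2, `CCOC(=O)C1CCCCN1S(=O)(=O)c1ccc(S(=O)(=O)N(CC)CC)cc1`, gives 12900 nM in this assay.
Compound 3, `CC(C)c1noc(N2CCN(C(=O)[C@@H]3CCCN(S(=O)(=O)c4ccc(S(=O)(=O)NC5CC5)cc4)C3)CC2)n1`, gives 6700 nM in this assay.

Of these three numbers, compound 1 has the highest. Its gap to compound 2 lies within the usual scatter of repeat measurements, so those two cannot be told apart on these data. Only compound 3 is separated from compound 1 beyond the scatter, with the lower number.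

Compound 4, `CCN1CC(NC(=O)[C@@H]2CCCN(S(=O)(=O)c3ccc(S(=O)(=O)N(CC)CC)cc3)C2)C1`, has not yet been measured. It differs from compound 1 in a single place: ethyl in place of cyclopropylcarbonyl on an amine nitrogen in a ring. The cyclopropylcarbonyl that sits on the amine nitrogen in the four-membered ring is replaced by an ethyl.

Going by the values given here, no measured pair in this set shows this same change, so there is no step to draw on. The expectation is that compound 4 stays close to compound 1 in this assay, with a step of a 1.1-fold lower number from compound 1 to compound 4 (0.04 log units; within the scatter) that does not go beyond the scatter. Compound 4 is therefore estimated at 17000 nM, in a range from 6000 nM to 50000 nM.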

Compound 4, half-maximal inhibitory concentration: > 30000 nM
Compound 4: a limit, no number; the forecaster's own chance of this, stated with the estimate: 20%; at least 1.7-fold (0.24 log units) between middle value and limit.
By their numbers in this assay, from the lowest: compounds 3, 2 and 1 (each within the scatter of the next, the first and the last beyond it). At a limit, above all of these: compound 4.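

In this assay, going by these compounds alone, ethyl in place of cyclopropylcarbonyl on the amine nitrogen of the four-membered ring gives an at least 1.6-fold higher number from compound 1 to compound 4 (0.20 log units; that floor lies within the scatter), the first step at this position, and its floor does not by itself separate the two compounds. The result for compound 4 is a limit, not a number: the limit of > 30000 nM in this assay, at which 1 of the 4 values shown sits. From the compounds shown here alone, the change therefore brings no lower number, and the true size of the step stays unknown, since it could be small or much larger than that floor.

The carbonyl and the three-membered ring leave together in this one change, so the compounds shown cannot tell which of them matters. An acetyl on this nitrogen would keep the carbonyl without the three-membered ring, while a cyclopropylmethyl would keep that ring without the carbonyl, and the two together would separate these parts.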